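Replacing a butylamino amide with a pyrrolidine in a longer chain

The source may report more compounds than this note shows. Statements on the series, on what has been measured and on what is new or still open speak of the compounds shown alone.

Of the compounds shown here, three sharing one core have been tested in a functional assay on U-937 cells (Homo sapiens) for antiproliferative activity, read by MTT assay, with a stated time of 24 h; on this read-out lower numbers stand for stronger inhibition and higher numbers for weaker inhibition. Compound 1, `CCCCNC(=O)COc1ccc(C(=O)c2c(CCCC)oc3ccccc23)cc1`, gives 22800 nM in this assay. Compound 2, `CCCCc1oc2ccccc2c1C(=O)c1ccc(OCC(=O)N2CCCC2)cc1`, gives 32500 nM in this assay. Compound 3, `CCCCNC(=O)CCCOc1ccc(C(=O)c2c(CCCC)oc3ccccc23)cc1`, gives 24600 nM in this assay.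

Compound 1 and compound 2 differ only in the group on the amide carbonyl: pyrrolidin-1-yl in place of butylamino on a carbonyl carbon. That change gave a 1.4-fold higher number from compound 1 to compound 2 (0.15 log units; within the scatter). Compound 1 and compound 3 differ in how far the amide sits from the aromatic oxygen: 2-(butylcarbamoyl)ethyl in place of butylcarbamoyl on a saturated chain carbon bound to an oxygen on an aromatic ring. That change gave a 1.1-fold higher number from compound 1 to compound 3 (0.03 log units; within the scatter). Between compound 2 and compound 3 the difference was a 1.3-fold lower number from compound 2 to compound 3 (0.12 log units; within the scatter).

Compound 4, `CCCCc1oc2ccccc2c1C(=O)c1ccc(OCCCC(=O)N2CCCC2)cc1`, has not yet been measured. It stands to compound 3 as compound 2 stands to compound 1: pyrrolidin-1-yl in place of butylamino on a carbonyl carbon. The surroundings of the changed carbonyl carbon are described in the same words in both pairs, so this is the same change made on a longer chain.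

Among the measured compounds shown here, the only guide is the one earlier instance of this change, and the small spread among all three measured numbers. From compound 3 to compound 4 the expected step is therefore a 1.3-fold higher number from compound 3 to compound 4 (0.13 log units; within the scatter), resting on a 1.4-fold higher number from compound 1 to compound 2 (0.15 log units; within the scatter). Compound 4 is accordingly expected to give about 33000 nM in this assay, with a plausible range from 15000 nM to 75000 nM.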

Compound 4, half-maximal inhibitory concentration: 7500 nM
Beside the measured number, compound 4's estimate is 4.4-fold (0.64 log units) above it; the measured number lies below the stated range.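

In this assay, putting pyrrolidin-1-yl in place of butylamino on the carbonyl carbon did not behave the same way on the two cores: the same change on two cores in this assay, a 1.4-fold higher number (0.15 log units; within the scatter) from compound 1 to compound 2 and a 3.3-fold lower number (0.52 log units; beyond the scatter) from compound 3 to compound 4, 4.7-fold (0.67 log units) apart, beyond the scatter of two such steps. On the longer chain the swap gives a 3.3-fold lower number from compound 3 to compound 4 (0.52 log units; beyond the scatter) and lengthening the chain while keeping pyrrolidin-1-yl gives a 4.3-fold lower number from compound 2 to compound 4 (0.64 log units; beyond the scatter) while making both changes together gives a 3.0-fold lower number from compound 1 to compound 4 (0.48 log units; beyond the scatter) and so compound 4 is the most potent of the four. Among the compounds shown here, this shows that the result of the swap on one core cannot simply be carried over to another, since the chain it sits on matters here, but it does not show why, and with only one pair on each chain it says nothing about how the swap would behave on any other chain.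

The compounds shown leave open whether the lower number on the longer chain is tied to the five-membered ring itself or to the loss of the amide hydrogen, which a piperidin-1-yl or a diethylamino amide on the same chain could help to separate. They also leave open whether a still longer chain carrying pyrrolidin-1-yl would lower the number further or raise it again.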